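A few compounds are considered here, and "the series" means these few. Any claim that something is new, unique, unknown or untested is made for them only; others in the source may bear on it.

Compound 1 `CO[C@@H]1CC=C2NN(c3ccc(C)cc3)C(=O)C[C@]2(C)O1` is the starting point. In a functional assay on DU-145 cells (Homo sapiens) for inhibition, read by sulforhodamine B assay, with a stated time of 48 h (on this read-out lower numbers stand for stronger inhibition and higher numbers for weaker inhibition), compound 1 gives 23200 nM, the highest of the three numbers measured. Compound 2 `COc1ccc(N2NC3=CC[C@@H](OC)O[C@@]3(c3ccccc3)CC2=O)cc1` gives 10100 nM in this assay, and compound 3 `CO[C@@H]1CC=C2NN(c3ccc(C)cc3)C(=O)C[C@]2(c2ccncc2)O1` gives 7100 nM. For the measured compounds named here, the only single-point step among them, a 3.3-fold lower number from compound 1 to compound 3 (0.51 log units; beyond the scatter), concerns pyridin-4-yl in place of methyl on a saturated ring carbon.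

Compound 4 `CO[C@@H]1CC=C2NN(c3ccc(Cl)cc3)C(=O)C[C@]2(C)O1` differs from compound 1 in another place: chloro in place of methyl on an aromatic carbon, that is, 4-methylphenyl becomes 4-chlorophenyl. Going by the values given here, no measured step touches this aromatic ring, so there is no direct guide, and no change beyond the scatter is expected in this assay. The number for compound 4 is therefore estimated at 20000 nM, with a range from 8000 nM to 50000 nM, which corresponds to an expected step of a 1.2-fold lower number from compound 1 to compound 4 (0.06 log units; within the scatter).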

Compound 4, half-maximal inhibitory concentration: 24200 nM
Compound 4: the middle estimate sits 1.2-fold (0.08 log units) below what was measured; the range from low to high includes it.
By their numbers in this assay, from the lowest: compounds 3 and 2 (each within the scatter of the next); then compounds 1 and 4 (each within the scatter of the next).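

The aromatic ring had not been touched by any earlier step, and here it gets its first reading: in this assay, 4-methylphenyl to 4-chlorophenyl gives a 1.0-fold higher number from compound 1 to compound 4 (0.02 log units; within the scatter). At this spot on the core of compound 1, chloro and methyl cannot be told apart, whereas the pyridin-4-yl step on the saturated ring carbon lay beyond the scatter. No measured evidence bears on this result. From the compounds shown here alone, whether an amine or a carboxylic acid at this spot would read differently stays open, as does whether chloro would read the same on the core of compound 3.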